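Methoxy to fluoro in a cytotoxicity-capped amide series

A few compounds are considered here, and "the series" means these few. Any claim that something is new, unique, unknown or untested is made for them only; others in the source may bear on it.

Compound 1, `CCS(=O)(=O)Nc1ccc(NC(=O)c2cccc(C(F)(F)F)c2)cc1OC`: 84800 nM
Compound 2, `CCS(=O)(=O)Nc1ccc(NC(=O)c2cc(C(F)(F)F)cc(C(F)(F)F)c2)cc1OC`: > 250000 nM
Compound 3, `COc1cc(NC(=O)c2cc(C(F)(F)F)cc(C(F)(F)F)c2)ccc1NS(=O)(=O)C(F)(F)F`: > 250000 nM

In an ADME assay on RAW264.7 cells (Mus musculus) for cytotoxicity, read by MTT assay, with a stated time of 48 h (a higher number here means a weaker inhibitor, a lower number a stronger inhibitor), compound 1 gives 84800 nM. Compound 2 does not give a number in this assay but only its limit, > 250000 nM. Compound 3 likewise sits at the limit, > 250000 nM. Compound 2 therefore stands at the ceiling of what this assay reports, a position it shares with compound 3, as the limit of > 250000 nM in this assay, at which 2 of the 3 values shown sit, shows. Two steps are measured. The first, an at least 2.9-fold higher number from compound 1 to compound 2 (0.46 log units; beyond the scatter), adds a trifluoromethyl group to the aromatic ring and pushes the reading up to the limit. The second, a step that the two limits leave unreadable from compound 2 to compound 3, stays at the limit on both sides, so its size cannot be read.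

Compound 4, `CCS(=O)(=O)Nc1ccc(NC(=O)c2cc(C(F)(F)F)cc(C(F)(F)F)c2)cc1F`, differs from compound 2 by fluoro in place of methoxy on an aromatic carbon. Within the data shown here, no measured step exchanges these two groups, so the expectation rests on compound 2 already sitting at the limit of > 250000 nM in this assay, at which 2 of the 3 values shown sit. Compound 4 is expected to give about 250000 nM, most likely between 100000 nM and 300000 nM. This expectation means a step of a number no higher from compound 2 to compound 4 (the limit leaves the size open), that is, no change beyond the scatter.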

Compound 4, half-maximal inhibitory concentration: > 250000 nM
Compound 4 gave a limit, no number; the forecaster's own chance of this, stated with the estimate: 70%; the middle value sits exactly at the limit.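

Compound 4, like compound 2, gives only a limit in this assay, so no size can be read for the change from methoxy to fluoro: the limit of > 250000 nM in this assay, at which 3 of the 4 values shown sit.

The compounds shown leave open how far either compound lies beyond that limit, and whether methoxy and fluoro differ here at all.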